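The compounds below may be only part of what the source reports. "The series", "measured", "known", "first", "only" and "open" are said of these compounds alone.

Among the measured compounds shown here, compound 3 `Nc1cc(N)c2nc(-c3ccccc3)c(NCc3ccc(F)cc3)nc2c1` gives 7590 nM in a functional assay on SF-268 cells (Homo sapiens) for inhibition, read by sulforhodamine B assay, with a stated time of 48 h (a lower number here means a stronger inhibitor of growth, a higher number a weaker inhibitor of growth), the lowest of the three numbers so far; compound 1 `Nc1cc(N)c2nc(-c3ccccc3)c(NCc3ccc(Cl)c(Cl)c3)nc2c1` gives 55000 nM and compound 2 `COc1ccc(CNc2nc3cc(N)cc(N)c3nc2-c2ccccc2)cc1OC` gives 60300 nM. Compound 4 `COc1ccc(CNc2nc3cc(N)cc(N)c3nc2-c2ccccc2)cc1` carries methoxy in place of fluoro on an aromatic carbon. For the measured compounds named here, two measured steps bear on this change: a 7.9-fold lower number from compound 2 to compound 3 (0.90 log units; beyond the scatter) and a 7.2-fold lower number from compound 1 to compound 3 (0.86 log units; beyond the scatter), both beyond the scatter, and both giving the lower number to the 4-fluorobenzyl compound. Compound 4 brings one methoxy back onto the benzyl ring, so a rise in the number is expected, though not all the way to compound 2, since only one of the two methoxy groups returns; the expected step is a 3.3-fold higher number from compound 3 to compound 4 (0.52 log units; beyond the scatter). Compound 4 is thus estimated at 25000 nM, with a range from 8000 nM to 80000 nM.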

Compound 4, concentration for total growth inhibition: 21900 nM
Compound 4: middle estimate off by 1.1-fold (0.06 log units), on the high side; the measured number falls inside the stated range.
By their numbers in this assay, from the lowest: compound 3; then compound 4; then compounds 1 and 2 (each within the scatter of the next).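

In this assay, a single change at the place para to a large group already moves the number: a 2.9-fold higher number from compound 3 to compound 4 (0.46 log units; beyond the scatter). The second methoxy also counts, since its removal gives a 2.8-fold lower number from compound 2 to compound 4 (0.44 log units; beyond the scatter), so the earlier gap does not rest on one methoxy alone. The 4-methoxybenzyl compound also separates from the 3,4-dichlorobenzyl compound, with a 2.5-fold lower number from compound 1 to compound 4 (0.40 log units; beyond the scatter).

No measurement on hand accounts for these steps. As far as these compounds go, how an amine or a longer ether chain such as ethoxy would read at this place remains open.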